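The source may report more compounds than this note shows. Statements on the series, on what has been measured and on what is new or still open speak of the compounds shown alone.

Of the compounds shown here, three sharing one core have been tested in a toxicity assay on THP-1 cells (Homo sapiens) for inhibition; a higher number here means that more compound is tolerated, a lower number that less compound is tolerated. Compound 1 `Cn1c(-c2ccc(F)cc2)cnc1NC(=O)c1ccc(F)cc1` gives only a limit in this assay, > 100000 nM. Compound 2 `COc1ccc(-c2cnc(NC(=O)c3ccc(F)cc3)n2C)cc1` also gives only a limit in this assay, >= 50000 nM. Compound 3 `Cc1cccc(-c2cnc(NC(=O)c3ccc(F)cc3)n2C)c1` likewise gives only a limit in this assay, > 100000 nM. Because the limit of > 100000 nM in this assay, at which 2 of the 3 values shown sit, and the limit of >= 50000 nM in this assay, at which 1 of the 3 values shown sits, are limits rather than numbers, the steps a step that the two limits leave unreadable from compound 1 to compound 2, a step that the two limits leave unreadable from compound 1 to compound 3 and a step that the two limits leave unreadable from compound 2 to compound 3 cannot be sized. Compound 2 therefore stands at a limit, as do both of its neighbours, and nothing shown sets it apart from them.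

Compound 4 `COc1ccc(-c2cnc(NC(=O)c3cccc(C)c3)n2C)cc1` differs from compound 2 by 3-methylphenyl in place of 4-fluorophenyl on a carbonyl carbon. Going by the values given here, no measured step makes this same change; the nearest, a step that the two limits leave unreadable from compound 1 to compound 3, swaps the same two groups on an aromatic carbon and is unreadable. With every shown value a limit, no step beyond the scatter is expected, and compound 4 is expected to stay at a limit, a step that the limit leaves unreadable from compound 2 to compound 4. Compound 4 is estimated at 100000 nM, in a range from 50000 nM to 300000 nM.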

Compound 4, half-maximal cytotoxic concentration: > 100000 nM
Compound 4 was reported as a limit (the forecaster's own chance of this, stated with the estimate: 85%); the middle value sits exactly at the limit.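

Compound 2 and compound 4 both give only limits in this assay, so the change to 3-methylphenyl in place of 4-fluorophenyl on a carbonyl carbon cannot be sized. The compounds shown leave open what concentration of any of them the cells fail to tolerate, and whether any of these changes matters.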